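The compounds below may be only part of what the source reports. "The series", "measured", "known", "first", "only" and "open" are said of these compounds alone.

Measured in a functional assay on DU-145 cells (Homo sapiens) for antiproliferative activity; a higher number here means a weaker inhibitor of growth, a lower number a stronger inhibitor of growth:
- compound 1 `CCCCCCNC(=O)c1cc(C#Cc2cc(OC)ccc2OC)ccc1OC`: > 100000 nM
- compound 2 `CCCCCCNC(=O)c1cc(/C=C\c2cc(O)ccc2O)ccc1O`: 10500 nM
- compound 3 `COC(=O)c1cc(/C=C\c2cc(OC)ccc2OC)ccc1OC`: 18100 nM

Compound 3 gives 18100 nM and compound 2 gives 10500 nM, and these two numbers lie within the usual scatter of each other. For compound 1, the reading of > 100000 nM is a limit of the assay and not a number.

The next compound to be tested is compound 4 `CCCCCCNC(=O)c1cc(/C=C\c2cc(OC)ccc2OC)ccc1OC`. It keeps the core of compound 3 but has hexylamino in place of methoxy on a carbonyl carbon, so methoxycarbonyl becomes hexylcarbamoyl: hexylamino in place of methoxy on a carbonyl carbon.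

Within the data shown here, no two measured compounds differ in this one place alone, so the size of the step has to be judged indirectly. Compound 2 already carries hexylcarbamoyl and gives 10500 nM, which offers no sign that this group on its own moves the number far from that of compound 3. Compound 1 carries it too, but it differs from compound 4 elsewhere as well. The expectation is therefore for little change, with no firm direction and probably nothing beyond the scatter. The estimated step is a 1.2-fold lower number from compound 3 to compound 4 (0.08 log units; within the scatter). Compound 4 is expected to give an estimated 15000 nM, within a range of 3000 nM to 70000 nM.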

Compound 4, concentration for 50% growth inhibition: 45600 nM
Compound 4: the middle estimate sits 3.0-fold (0.48 log units) below what was measured, and the stated range covers the measured number.
By their numbers in this assay, from the lowest: compounds 2 and 3 (each within the scatter of the next); then compound 4. At a limit, above all of these: compound 1.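

In this assay, among these compounds, replacing methoxy with hexylamino on the carbonyl carbon gives the first direct reading of this change: a 2.5-fold higher number from compound 3 to compound 4 (0.40 log units; beyond the scatter). Within this pair, the methoxycarbonyl compound is therefore the stronger inhibitor of growth, so hexylcarbamoyl brings no gain at this position on this core, although the step is only modest. Among the compounds shown here, compound 4 still gives a real number rather than a limit, so this step can be read as a size and not just a direction, and the ceiling of the measurement is reached by only one compound: the limit of > 100000 nM in this assay, at which 1 of the 4 values shown sits.

This single step cannot separate the length of the hexyl chain from the change of methoxycarbonyl to an amide that carries an amide hydrogen, and a methylamino group or a carboxylic acid on the same carbonyl carbon would help to tell these apart. Whether the same step would appear on a core carrying hydroxy groups, as compound 2 does, also stays open, and the numbers shown cannot settle it.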